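The source may hold more compounds than are shown below. What is called first, only, known or untested is meant among the compounds shown, and "the series" means these compounds.

Of the compounds shown here, two have so far been tested in a functional assay on ACHN cells (Homo sapiens) for cytotoxicity, read by MTT assay, with a stated time of 48 h; a higher number here means a weaker inhibitor, a lower number a stronger inhibitor. Compound 1 `COc1ccc2nc(NC(=O)c3cc(-c4ccc(OC)c(OC)c4)n4nc(-c5ccccc5)cc4n3)sc2c1` gives 13300 nM in this assay. Compound 2 `Cc1cc2nc(NC(=O)c3cc(-c4ccc(F)cc4)n4nc(-c5ccccc5)cc4n3)sc2cc1C` gives 33000 nM, the higher of the two numbers, with a gap to compound 1 beyond the usual scatter. Compound 3 `COc1ccc(-c2cc(C(=O)Nc3nc4cc(C)c(C)cc4s3)nc3cc(-c4ccccc4)nn23)cc1OC` differs from compound 2 in one change: 3,4-dimethoxyphenyl in place of 4-fluorophenyl on an aromatic carbon, the same group that compound 1 carries. Because compound 1 gives 13300 nM with that group, a modest lowering of the number is expected, a 1.8-fold lower number from compound 2 to compound 3 (0.26 log units; within the scatter). Compound 3 is therefore estimated at 18000 nM, with a likely range from 7000 nM to 45000 nM.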

Compound 3, half-maximal inhibitory concentration: 8700 nM
Beside the measured number, compound 3's estimate is 2.1-fold (0.32 log units) above it; the range from low to high includes it.
By their numbers in this assay, from the lowest: compounds 3 and 1 (each within the scatter of the next); then compound 2.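

In this assay, 3,4-dimethoxyphenyl in place of 4-fluorophenyl on this aromatic carbon gives a 3.8-fold lower number from compound 2 to compound 3 (0.58 log units; beyond the scatter), a single change that could not be isolated earlier, since compound 1 and compound 2 differ in two places. With 3,4-dimethoxyphenyl held fixed, 5,6-dimethyl-1,3-benzothiazol-2-yl in place of 6-methoxy-1,3-benzothiazol-2-yl on the amide-type nitrogen gives a 1.5-fold lower number from compound 1 to compound 3 (0.18 log units; within the scatter), so that swap shows no clear effect. No available evidence explains either step. Going by these compounds, it remains open how a phenyl ring carrying an amine or a carboxylic acid would behave at this position.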